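Hydrazone aryl swaps in a pyridyl-triazole thioacetohydrazide series

The compounds below may be only part of what the source reports. "The series", "measured", "known", "first", "only" and "open" are said of these compounds alone.

Notes on compound 3 `O=C(CSc1nnc(-c2ccncc2)n1-c1ccccc1)N/N=C/c1ccccc1O` and compound 4 `O=C(CSc1nnc(-c2ccncc2)n1-c1ccccc1)N/N=C/C=C/c1ccccc1`. In a functional assay on HCT-116 cells (Homo sapiens) for inhibition, read by MTT assay, with a stated time of 48 h (on this read-out lower numbers stand for stronger inhibition and higher numbers for weaker inhibition), compound 3 gives 7060 nM, the second highest of three numbers; compound 1 `COc1ccc(/C=N/NC(=O)CSc2nnc(-c3ccncc3)n2-c2ccccc2)cc1` gives 19200 nM and compound 2 `O=C(CSc1nnc(-c2ccncc2)n1-c1ccccc1)N/N=C/c1ccc(Cl)cc1` gives 5740 nM. The change a 2.7-fold lower number from compound 1 to compound 3 (0.43 log units; beyond the scatter) is modest, and a 1.2-fold higher number from compound 2 to compound 3 (0.09 log units; within the scatter) sits within the scatter. The step to compound 4 is 2-phenylethenyl in place of 2-hydroxyphenyl on a carbon with a double bond to nitrogen. Both measured steps bear on it, as each alters the group on the carbon with a double bond to nitrogen, and neither moved this assay by more than a modest amount. A comparable outcome is therefore expected: compound 4 is estimated at 6000 nM in this assay, with a range of 2500 nM to 15000 nM, which means an expected step of a 1.2-fold lower number from compound 3 to compound 4 (0.07 log units; within the scatter).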

Compound 4, half-maximal inhibitory concentration: 6150 nM
The estimate for compound 4 lay 1.0-fold (0.01 log units) below the measured number; measured number inside the range.
By their numbers in this assay, from the lowest: compounds 2, 4 and 3 (each within the scatter of the next); then compound 1.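

In this assay the carbon with a double bond to nitrogen accepts 2-phenylethenyl, with its double bond outside aromatic rings, giving a 1.1-fold lower number from compound 3 to compound 4 (0.06 log units; within the scatter) and a 1.1-fold higher number from compound 2 to compound 4 (0.03 log units; within the scatter) in turn. The entering group has no hydrogen-bond donors or acceptors, so the hydroxy of compound 3 is not required for this level of inhibition, while 4-methoxyphenyl remains apart, with a 3.1-fold lower number from compound 1 to compound 4 (0.49 log units; beyond the scatter) as the step. No evidence here explains why these groups read alike.

Open, on these data alone, is whether an amine or a carboxylic acid in this group, or a chain longer than 2-phenylethenyl, would move the number beyond the scatter of compounds 2, 3 and 4.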